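The compounds below may be only part of what the source reports. "The series", "measured", "known", "first", "only" and "open" are said of these compounds alone.

The shared core of these compounds carries a five-membered aromatic ring with 3 nitrogen, and on one of its carbons sits a group that is varied; the effect of that group is followed in a functional assay on MCF7 cells (Homo sapiens) for antiproliferative activity, read by MTT assay, with a stated time of 24 h; on this read-out lower numbers stand for stronger inhibition and higher numbers for weaker inhibition. Compound 1 `O=C1NC(O)(CCn2cc(C3=CCCCC3)nn2)C(OCc2ccccc2)=C1OCc1ccccc1` bears a cyclohex-1-en-1-yl group, and in this assay compound 1 reaches only > 100000 nM, which is a limit of the assay and not a number. Compound 2 `CC(C)(C)c1ccc(-c2cn(CCC3(O)NC(=O)C(OCc4ccccc4)=C3OCc3ccccc3)nn2)cc1` bears a 4-(tert-butyl)phenyl group, and in this assay compound 2 gives 25100 nM. Compound 3 `O=C1NC(O)(CCn2cc(Cc3ccccc3)nn2)C(OCc2ccccc2)=C1OCc1ccccc1` bears a benzyl group, and in this assay compound 3 gives 39200 nM. Of the two actual numbers, compound 3 has the higher one, but the gap a 1.6-fold higher number from compound 2 to compound 3 (0.19 log units; within the scatter) is within the scatter, so the two compounds cannot be told apart. Both stand clearly away from the limit of compound 1, as an at least 3.9-fold lower number from compound 1 to compound 2 (0.60 log units; beyond the scatter) and an at least 2.5-fold lower number from compound 1 to compound 3 (0.40 log units; beyond the scatter) show.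

Compound 4 `Cc1ccc(-c2cn(CCC3(O)NC(=O)C(OCc4ccccc4)=C3OCc3ccccc3)nn2)cc1` is built from compound 3 by the change (4-methylphenyl in place of benzyl on an aromatic carbon). The measured step that bears on this is a 1.6-fold higher number from compound 2 to compound 3 (0.19 log units; within the scatter), which exchanged a benzyl for another aromatic ring on the same carbon and stayed within the scatter. Compound 4 likewise carries an aromatic ring directly on that carbon, as compound 2 does, so the expected step of a 1.4-fold lower number from compound 3 to compound 4 (0.15 log units; within the scatter) is none beyond the scatter. Compound 4 is therefore estimated at 28000 nM, with a range from 12000 nM to 70000 nM.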

Compound 4, half-maximal inhibitory concentration: 24000 nM
Compound 4: middle estimate off by 1.2-fold (0.07 log units), on the high side, and the stated range covers the measured number.
By their numbers in this assay, from the lowest: compounds 4, 2 and 3 (each within the scatter of the next). At a limit, above all of these: compound 1.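

In this assay, the swap from benzyl to 4-methylphenyl keeps the same seven carbons but joins them differently, and a 1.6-fold lower number from compound 3 to compound 4 (0.21 log units; within the scatter) shows that this rearrangement on the five-membered ring cannot be told apart from no effect. The outer end of the aromatic group also gives no detectable signal here: with methyl in place of tert-butyl, a 1.0-fold lower number from compound 2 to compound 4 (0.02 log units; within the scatter) is likewise within the scatter, so two quite different alkyl groups on that ring leave the read-out where it was. Compounds 2, 3 and 4, which all carry a six-membered aromatic ring of carbon only, now form one group that cannot be separated, while compound 1, which lacks such a ring, stays apart, with an at least 4.1-fold lower number from compound 1 to compound 4 (0.61 log units; beyond the scatter) read against a limit rather than a number: the limit of > 100000 nM in this assay, at which 1 of the 4 values shown sits.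

All the groups shown at this carbon contain only carbon and hydrogen, so it remains open whether an amine or a carboxylic acid in place of the methyl of compound 4 would move the number beyond the scatter. Going by these compounds, it is also open how a longer chain in place of the benzyl of compound 3 would behave.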